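This account rests on a few compounds, and the source may have more. Where it says the series, first, only, none or still open, it means among the compounds named here.

In a functional assay on HepG2 cells (Homo sapiens) for cytotoxicity, read by MTT assay, with a stated time of 48 h (on this read-out higher numbers stand for weaker inhibition and lower numbers for stronger inhibition), compound 2 `C=CCNc1n[n+]([O-])c2ccccc2[n+]1[O-]` reaches only the limit of the measurement, > 56000 nM. Compound 1 `CCCCCCCCNc1n[n+]([O-])c2ccccc2[n+]1[O-]` gives 17400 nM and compound 3 `O=[N+]([O-])c1ccc(CNc2n[n+]([O-])c3ccccc3[n+]2[O-])cc1` gives 7700 nM. Compound 4 `CCNc1n[n+]([O-])c2ccccc2[n+]1[O-]` differs from compound 2 by methyl in place of vinyl on a saturated chain carbon bound to a nitrogen on an aromatic ring. Among the measured compounds shown here, the single measured step that bears on this change is an at least 3.2-fold higher number from compound 1 to compound 2 (0.50 log units; beyond the scatter), in which the shorter chain went with the higher number, as far as the limit of > 56000 nM in this assay, at which 1 of the 3 values shown sits, allows one to see. A further shortening to ethyl is therefore expected to keep compound 4 at that same limit, an expected step that the limit leaves unreadable from compound 2 to compound 4. Compound 4 is estimated at 80000 nM, within 30000 nM to 200000 nM.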

Compound 4, half-maximal inhibitory concentration: 13500 nM
The estimate for compound 4 lay 5.9-fold (0.77 log units) above the measured number; measured number outside the range, below it.
By their numbers in this assay, from the lowest: compounds 3, 4 and 1 (each within the scatter of the next, the first and the last beyond it). At a limit, above all of these: compound 2.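

Methyl in place of vinyl on this saturated chain carbon gives an at least 4.1-fold lower number from compound 2 to compound 4 (0.61 log units; beyond the scatter), so the earlier link between a shorter chain and a higher number does not hold, and compound 4 goes against it. Hydrogen in place of hexyl at the neighbouring chain carbon gives no readable difference: a 1.3-fold lower number from compound 1 to compound 4 (0.11 log units; within the scatter). Compound 2 alone stands at a limit: the limit of > 56000 nM in this assay, at which 1 of the 4 values shown sits.

Whether the double bond of the allyl group goes with that limit stays open, since a propyl chain is not among the compounds shown. On these data alone, how an amine or a carboxylic acid at the end of the chain would read also stays open.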